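The source may hold more compounds than are shown below. What is called first, only, known or untested is meant among the compounds shown, and "the series" means these compounds.

Measured so far:
- compound 1, `COc1ccc(/C=N/NC(=O)Nc2ccc(Oc3ccnc(-c4nncn4CCN(C)C)c3)c(F)c2)c(OC)c1`: 2820 nM
- compound 2, `CN(C)CCn1cnnc1-c1cc(Oc2ccc(NC(=O)N/N=C/c3ccc(O)c(Br)c3)cc2F)ccn1`: 1370 nM
- compound 3, `CN(C)CCn1cnnc1-c1cc(Oc2ccc(NC(=O)N/N=C/c3cccc(Cl)c3Cl)cc2F)ccn1`: 1090 nM

All three share one core and differ only in the aromatic ring attached to the carbon that carries a double bond to nitrogen. In a functional assay on A549 cells (Homo sapiens) for cytotoxicity, read by MTT assay, with a stated time of 72 h (a lower number here means a stronger inhibitor, a higher number a weaker inhibitor), compound 3 gives the lowest of the three numbers; its nearest neighbour is compound 2, and the gap a 1.3-fold lower number from compound 2 to compound 3 (0.10 log units; within the scatter) lies within the scatter, so the two cannot be ranked. Against compound 1 the distance is clearer: a 2.6-fold lower number from compound 1 to compound 3 (0.41 log units; beyond the scatter) and, for compound 2, a 2.1-fold lower number from compound 1 to compound 2 (0.31 log units; beyond the scatter).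

Compound 4, `CN(C)CCn1cnnc1-c1cc(Oc2ccc(NC(=O)N/N=C/c3cccc(Br)c3)cc2F)ccn1`, has not yet been measured. Its difference from compound 3 is 3-bromophenyl in place of 2,3-dichlorophenyl on a carbon with a double bond to nitrogen. Within the data shown here, no measured step swaps one halogenated ring for another, so the closest guidance is that replacing the 2,4-dimethoxyphenyl of compound 1 by either halogenated ring gave only modest steps, and the two halogenated rings themselves sit within the scatter of each other. For compound 4 in this assay a step of about a 1.3-fold higher number from compound 3 to compound 4 (0.11 log units; within the scatter) is therefore expected, likely not beyond the scatter. The estimated value for compound 4 is 1400 nM, with a range from 600 nM to 3500 nM.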

Compound 4, half-maximal inhibitory concentration: 970 nM
Estimate against measurement, compound 4: 1.4-fold (0.16 log units) above; the range from low to high includes it.
By their numbers in this assay, from the lowest: compounds 4, 3 and 2 (each within the scatter of the next); then compound 1.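

In this assay, a 1.1-fold lower number from compound 3 to compound 4 (0.05 log units; within the scatter) lies within the scatter, so a ring carrying one bromine cannot be told apart from a ring carrying two chlorines at this carbon with a double bond to nitrogen. Likewise, a 1.4-fold lower number from compound 2 to compound 4 (0.15 log units; within the scatter) is within the scatter when hydrogen takes the place of hydroxy on the aromatic carbon, so the number does not show that this hydroxy matters here. The 2,4-dimethoxyphenyl ring stays apart, with a 2.9-fold lower number from compound 1 to compound 4 (0.46 log units; beyond the scatter) beyond the scatter but still modest, while compounds 2, 3 and 4 remain unranked.

Still open, as far as these compounds go, is how a plain phenyl ring, or a ring bearing an amine or a carboxylic acid, would compare at this position. Nothing available here explains why these halogenated rings give such similar numbers.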